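Nitro for Amino on an Indole Chalcone Core

The source may hold more compounds than are shown below. What is called first, only, known or untested is meant among the compounds shown, and "the series" means these compounds.

Compound 1 `COc1ccc2c(/C=C/C(=O)c3cc(N)c(OC)c(OC)c3)c[nH]c2c1` was tested in a functional assay on HeLa cells (Homo sapiens) for antiproliferative activity, read by MTT assay, with a stated time of 48 h (a lower number here means a stronger inhibitor, a higher number a weaker inhibitor), where compound 1 gives 155 nM. Its nitro partner, compound 2 `COc1ccc2c(/C=C/C(=O)c3cc(OC)c(OC)c([N+](=O)[O-])c3)c[nH]c2c1`, gives 850 nM in this assay; the step of a 5.5-fold higher number from compound 1 to compound 2 (0.74 log units; beyond the scatter) is a single change, (nitro in place of amino on an aromatic carbon).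

Compound 3 `COc1cc(C(=O)/C=C/c2cn(C)c3ccccc23)cc(N)c1OC` shares much with compound 1, but the difference between the two cores is not broken down here. In this assay compound 3 gives 668 nM.

Compound 4 `COc1cc(C(=O)/C=C/c2cn(C)c3ccccc23)cc([N+](=O)[O-])c1OC` awaits measurement. Its change from compound 3, (nitro in place of amino on an aromatic carbon), is the same change that led from compound 1 to compound 2. Because compound 1 to compound 2 went a 5.5-fold higher number from compound 1 to compound 2 (0.74 log units; beyond the scatter), a step of about a 4.5-fold higher number from compound 3 to compound 4 (0.65 log units; beyond the scatter) from compound 3 to compound 4 is expected. Compound 4 is therefore estimated at 3000 nM, expected between 1200 nM and 8000 nM.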

Compound 4, half-maximal inhibitory concentration: 1960 nM
Beside the measured number, compound 4's estimate is 1.5-fold (0.18 log units) above it; low and high end bracket the measured number.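

In this assay, putting nitro in place of amino again makes the compound a weaker inhibitor, with a 2.9-fold higher number from compound 3 to compound 4 (0.47 log units; beyond the scatter). The size of the step also carries over from one core to the other, as far as repeated measurements of this kind can tell: the same change on two cores in this assay, a 5.5-fold higher number (0.74 log units; beyond the scatter) from compound 1 to compound 2 and a 2.9-fold higher number (0.47 log units; beyond the scatter) from compound 3 to compound 4, 1.9-fold (0.27 log units) apart, within the scatter of two such steps

For the compounds shown here, this rests on only two cores, so it does not show that the change would act the same way on a third core, and it does not explain why the amino compounds give the lower numbers.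

The compounds shown leave open how another group on that aromatic carbon, such as a hydroxyl, a methylamino group or an acetamide, would compare with amino and nitro. The differences between the two cores also remain unsplit into single changes.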